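Sulfonamide series sitting at the assay limit

This account rests on a few compounds, and the source may have more. Where it says the series, first, only, none or still open, it means among the compounds named here.

Compound 3 `Cc1cccc(S(=O)(=O)Nc2ccc3oc(-c4ccccc4)nc3c2)c1` is one of three sulfonamides on a shared core. In an assay on cells for inhibition of HSP60/HSP10 (Homo sapiens), with a stated time of 60 min (on this read-out higher numbers stand for weaker inhibition and lower numbers for stronger inhibition), compound 3 gives only a limit, > 100000 nM. Compound 1 `O=S(=O)(Nc1ccc2oc(-c3ccccc3)nc2c1)c1cccc(Cl)c1` also gives only a limit in this assay, > 100000 nM. Compound 2 `O=S(=O)(Nc1ccc2oc(-c3ccccc3)nc2c1)c1ccc(Cl)c(Cl)c1` likewise gives only a limit, > 100000 nM. Compound 3 thus stands where every measured value sits: the limit of > 100000 nM in this assay, at which 3 of the 3 values shown sit. The steps a step that the two limits leave unreadable from compound 1 to compound 2, a step that the two limits leave unreadable from compound 1 to compound 3 and a step that the two limits leave unreadable from compound 2 to compound 3 are all unreadable. Compound 4 `O=S(=O)(Nc1ccc2oc(-c3ccccc3)nc2c1)c1ccc(Cl)s1` is unmeasured; it differs from compound 3 by 5-chlorothiophen-2-yl in place of 3-methylphenyl on a sulfonyl sulfur. Among the compounds with values here, no measured step touches a thiophene, and none was readable, so neither size nor direction can be taken from them. Compound 4 is therefore expected to remain at the limit, estimated at 100000 nM (range 30000 nM to 300000 nM). The expected step of a number no higher from compound 3 to compound 4 (the limit leaves the size open) is flat.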

Compound 4, half-maximal inhibitory concentration: 70000 nM
The estimate for compound 4 lay 1.4-fold (0.15 log units) above the measured number; low and high end bracket the measured number.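

Compound 4 is the only one of the four to give a number rather than a limit in this assay with 5-chlorothiophen-2-yl on the sulfonyl sulfur. The steps are an at least 1.4-fold lower number from compound 3 to compound 4 (0.15 log units; that floor lies within the scatter) and an at least 1.4-fold lower number from compound 2 to compound 4 (0.15 log units; that floor lies within the scatter) and an at least 1.4-fold lower number from compound 1 to compound 4 (0.15 log units; that floor lies within the scatter) as floors only, so their true sizes stay unread. Compound 1, compound 2 and compound 3 each remain a limit: the limit of > 100000 nM in this assay, at which 3 of the 4 values shown sit.

From the compounds shown here alone, whether the number belongs to the five-membered ring or to its chlorine stays open. So does what an amine or a carboxylic acid on the sulfonyl side would give.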